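The source may hold more compounds than are shown below. What is called first, only, known or untested is meant among the compounds shown, and "the series" means these compounds.

Working notes on a small set of pyrazole-linked compounds tested in a functional assay on NCI-H460 cells (Homo sapiens) for cytotoxicity, read by sulforhodamine B assay, with a stated time of 48 h, tested at 0.01 uM; a lower number here means a stronger effect, a higher number a weaker effect of the compound at the concentration tested.

Going by the values given here, the three numbers so far sit close together. Compound 1 `COc1cc(C)cc(-c2c(-c3ccnc(-c4ccc(C(C)=O)cc4)c3)cnn2CC#N)c1` gives 98%. Compound 2 `Cc1cc(O)cc(-c2nn(CC#N)cc2-c2ccnc(-c3ccc(Oc4ccccc4)cc3)c2)c1` gives 100%. Compound 3 `COc1cc(C)cc(-c2nn(CC#N)cc2-c2ccnc(-c3ccc(N(C)C)cc3)c2)c1` gives 106%. Compound 3 stands at the upper end of the three, but the gap to compound 2 and the gap to compound 1 both lie within the scatter, so the three compounds cannot be told apart in this assay and none of them shows a meaningful effect at the concentration tested.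

The next compound, compound 4 `Cc1cc(O)cc(-c2nn(CC#N)cc2-c2ccnc(-c3ccc(N(C)C)cc3)c2)c1`, is compound 3 with one change: hydrogen in place of methyl on an oxygen on an aromatic ring. The same hydroxy already appears in compound 2 alongside a different group on the far phenyl ring, and compound 2 gives 100%, which is no different from the methoxy analogue compound 1 within the scatter.

Among the compounds with values here, no step between measured compounds is available for this change. From what compound 1, compound 2 and compound 3 show, no step beyond the scatter is expected from compound 3 to compound 4, so a number 6 percentage points lower from compound 3 to compound 4 (within the scatter) is the expected size. Compound 4 is therefore estimated to give 100%, with a range from 88% to 112%.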

Compound 4, a percentage reported as activity, at one concentration (the size of the read-out at that concentration, not a potency): 102%
Compound 4: the middle estimate sits 2 percentage points below what was measured; measured number inside the range.
By their numbers in this assay, from the lowest: compounds 1, 2, 4 and 3 (each within the scatter of the next).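

In this assay the change from methoxy to hydroxy now has a direct reading, as a number 4 percentage points lower from compound 3 to compound 4 (within the scatter) shows that, with the dimethylamino group held constant, replacing methyl with hydrogen on this oxygen leaves the read-out within the scatter. With the hydroxy held constant, dimethylamino in place of phenoxy on an aromatic carbon gives a number 2 percentage points higher from compound 2 to compound 4 (within the scatter) and so also stays within the scatter, which means that neither of the two single changes read so far separates its pair at this concentration. No supporting data bear on this result.

Because all four compounds give similar numbers at a single low concentration, the shown data leave open whether either change would matter at a concentration where the series produces a clear effect. On these data alone, it also remains open how the read-out would respond to a carboxylic acid or a morpholine in place of dimethylamino, or to an ethoxy group or an amine in place of the methoxy or hydroxy group.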